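A few compounds are considered here, and "the series" means these few. Any claim that something is new, unique, unknown or untested is made for them only; others in the source may bear on it.

Working notes on the series. In a functional assay on MV4-11 cells (Homo sapiens) for antiproliferative activity, read by CellTiter-Glo, with a stated time of 72 h (a lower number here means a stronger inhibitor of growth, a higher number a weaker inhibitor of growth), compound 2 (`COCCN[C@H]1CC[C@H](Nc2cc(-c3csc(NCC4CCC4)n3)c(Cl)cn2)CC1`) gives > 10000 nM as a limit of the assay and not a number. Compound 1 (`COCCN[C@H]1CC[C@H](Nc2cc(-c3csc(OCC4CCOCC4)n3)c(Cl)cn2)CC1`) gives 570 nM in this assay as a measured number. For the measured compounds named here, the one measured step, (cyclobutylmethyl)amino in place of (oxan-4-yl)methoxy, is large and beyond the scatter (an at least 17-fold higher number from compound 1 to compound 2 (1.24 log units; beyond the scatter)). Compound 3 (`COCCN[C@H]1CC[C@H](Nc2cc(-c3csc(NCC4CCCCC4)n3)c(Cl)cn2)CC1`) keeps the rest of compound 2 and carries one change: cyclohexyl in place of cyclobutyl on a saturated chain carbon bound to a nitrogen on an aromatic ring. The measured step concerns a different change and bears only indirectly, so no step beyond the scatter is expected in this assay, and no direction is favoured. The estimated step is small (an at least 1.1-fold lower number from compound 2 to compound 3 (0.04 log units; that floor lies within the scatter)) and a second limit is as likely as a number. For compound 3 the estimate is 9000 nM (expected range 2500 nM to 30000 nM).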

Compound 3, concentration for 50% growth inhibition: 820 nM
Compound 3: middle estimate off by 11-fold (1.04 log units), on the high side; the whole stated range lies above it.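

In this assay, the amino-linked series turns out to be sensitive to the ring on the saturated chain carbon bound to a nitrogen on an aromatic ring: an at least 12-fold lower number from compound 2 to compound 3 (1.08 log units; beyond the scatter). The loss seen with (cyclobutylmethyl)amino therefore does not extend to the amino link as such, since the comparison with the ether-linked compound gives a 1.4-fold higher number from compound 1 to compound 3 (0.16 log units; within the scatter), so (cyclohexylmethyl)amino and (oxan-4-yl)methoxy cannot be told apart here. The size of the cyclobutyl to cyclohexyl step is only a floor, as compound 2 gives a limit and not a number: the limit of > 10000 nM in this assay, at which 1 of the 3 values shown sits.

Going by these compounds, with only cyclobutyl and cyclohexyl on this chain, it remains open where cyclopentyl would fall between them. Also open, on these data alone, is whether (oxan-4-yl)methylamino, carrying the oxygen-containing ring on the amino link, would keep the growth inhibition of compound 3.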